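A few compounds are considered here, and "the series" means these few. Any claim that something is new, unique, unknown or untested is made for them only; others in the source may bear on it.

In an ADME assay on SK-OV-3 cells (Homo sapiens) for cytotoxicity, read by sulforhodamine B assay, with a stated time of 48 h, tested at 10 uM (on this read-out lower numbers stand for less inhibition and higher numbers for more inhibition at the one concentration tested (going by the name of the read-out)), compound 1 `COc1nc2ccc(Br)cc2cc1C(c1ccccc1)n1cc(-c2cccc(F)c2)nn1` gives 12.7% and compound 2 `CCCCCCCCc1cn(C(c2ccccc2)c2cc3cc(Br)ccc3nc2OC)nn1` gives 2.06%. Among the compounds with values here, the one measured step, a number 10.6 percentage points lower from compound 1 to compound 2 (beyond the scatter), exchanges an aryl group for a chain and is the only comparison available. Compound 2 stands lowest of the two numbers, with compound 1 its nearest neighbour, the gap being beyond the scatter. Compound 3 `CCCCCCc1cn(C(c2ccccc2)c2cc3cc(Br)ccc3nc2OC)nn1` trims the chain of compound 2: hydrogen in place of ethyl on a saturated chain carbon, six bonds along the chain from an aromatic carbon. Within the data shown here, no measured step bears on shortening an alkyl chain, so no step beyond the scatter is expected in this assay. The step is expected to be a number 1.9 percentage points higher from compound 2 to compound 3 (within the scatter), within the scatter. Compound 3 is estimated at 4%, with a range from -5% to 15%.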

Compound 3, a percentage reported as inhibition, at one concentration (the size of the read-out at that concentration, not a potency): 7.17%
Beside the measured number, compound 3's estimate is 3.2 percentage points below it; measured number inside the range.
By their numbers in this assay, from the lowest: compounds 2, 3 and 1 (each within the scatter of the next, the first and the last beyond it).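

In this assay, hexyl in place of octyl, read as hydrogen in place of ethyl on the chain, gives a number 5.1 percentage points higher from compound 2 to compound 3 (within the scatter) and so shows no resolved dependence on chain length for this pair. Hexyl in place of 3-fluorophenyl gives a number 5.5 percentage points lower from compound 1 to compound 3 (within the scatter) and so, unlike octyl, is not separated from the aryl group at this position. Nothing measured explains either step.

Open at this position is whether a decyl chain, or a chain ending in an amine or a carboxylic acid, would move the number beyond the scatter.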